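The source may hold more compounds than are shown below. What is called first, only, known or untested is meant among the compounds shown, and "the series" means these compounds.

Of the compounds shown here, two share one core and have been measured in an in vitro assay on HEK-293T cells for antagonist activity at transient receptor potential cation channel subfamily V member 1 (Rattus norvegicus), read by fluorescence and calcium flux, with a stated time of 30 min; on this read-out higher numbers stand for weaker inhibition and lower numbers for stronger inhibition. Compound 1 `CCCCCCCC(=O)Nc1nnc(-c2cc(I)c(O)c(OC)c2)s1` gives 1.09 nM in this assay. Compound 2 `CCCCCCCCC(=O)Nc1nnc(-c2cc(I)c(O)c(OC)c2)s1`, which carries one more carbon on its chain, gives 0.15 nM in this assay, the lowest of the two numbers recorded, and the step of a 7.3-fold lower number from compound 1 to compound 2 (0.86 log units; beyond the scatter) shows how far the two lie apart.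

Compound 3 `CCCCCCCCC(=O)Nc1nnc(-c2ccc(O)c(OC)c2)s1` has not yet been measured. Against compound 2 it shows (hydrogen in place of iodo on an aromatic carbon). Going by the values given here, the only measured step, the chain extension from compound 1 to compound 2, changes a different part of the molecule and so says nothing about what happens when the iodo group is taken away. No measured comparison in this set bears on the new change, and the expectation therefore rests on little.

With that caution, compound 3 is expected to give about 3 nM in this assay, within a range from 0.3 nM to 30 nM. The step from compound 2 to compound 3 is thus estimated as a 20-fold higher number from compound 2 to compound 3 (1.30 log units; beyond the scatter), a rise in the number, though the width of the range reflects how little the measured data constrain it.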

Compound 3, half-maximal inhibitory concentration: 0.05 nM
Compound 3: middle estimate off by 60-fold (1.78 log units), on the high side; measured number outside the range, below it.
By their numbers in this assay, from the lowest: compound 3; then compound 2; then compound 1.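

Removing the iodo group from the aromatic carbon ortho to the hydroxy group gives a 3.0-fold lower number from compound 2 to compound 3 (0.48 log units; beyond the scatter) in this assay and does not weaken inhibition. On the chain carried by compound 2 and compound 3, the iodo group is therefore not needed for inhibition at this level, and plain hydrogen on this carbon gives the lower number, by a step beyond the usual scatter. Going by these compounds alone, the only earlier step concerned chain length, so this is the first measured view of the aromatic ring, and no measurement offered here explains why the number falls when the iodine atom leaves.

The compounds shown leave open whether the same exchange would move the number in the same direction on the shorter chain of compound 1, since a change at one place need not carry over unchanged when another place differs. They also leave open how a fluoro, chloro, bromo or methyl group on this same aromatic carbon would compare with iodo and with hydrogen, and so whether the trend between these two groups extends to any others.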